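Extending compound 1 with a (methoxycarbonyl)amino group

The source may report more compounds than this note shows. Statements on the series, on what has been measured and on what is new or still open speak of the compounds shown alone.

Among the compounds with values here, compound 1 `O=C(O)c1ccc(CN2CCC[C@H](O[C@H](CO)c3cc(Cl)cc(Cl)c3)[C@@H]2c2ccccc2)cc1` is the only compound with a numerical value: in an assay on isolated protein for activation of cGMP-dependent protein kinase 1 (Homo sapiens), read by ADP-Glo, with stated times of 30 min and 2 h (on this read-out lower numbers stand for an effect already at smaller amounts and higher numbers for an effect only at larger amounts of compound), compound 1 gives 77000 nM. Compound 2 `OC[C@@H](O[C@H]1CCCN(Cc2nc3ccccc3[nH]2)[C@H]1c1ccccc1)c1cc(Cl)cc(Cl)c1` reaches only a limit of the assay; in this assay compound 2 gives > 200000 nM. Within the data shown here, the single measured step, an at least 2.5-fold higher number from compound 1 to compound 2 (0.41 log units; beyond the scatter), exchanges the whole group and is known only as a lower bound due to the limit of > 200000 nM in this assay, at which 1 of the 2 values shown sits. Compound 3 `COC(=O)Nc1cc(C(=O)O)ccc1CN1CCC[C@H](O[C@H](CO)c2cc(Cl)cc(Cl)c2)[C@@H]1c1ccccc1` differs from compound 1 by (methoxycarbonyl)amino in place of hydrogen on an aromatic carbon. Among the measured compounds shown here, no measured step touches this change, so for compound 3 a step within the scatter is expected in this assay: a 1.3-fold lower number from compound 1 to compound 3 (0.11 log units; within the scatter). Compound 3 is estimated at 60000 nM, between 20000 nM and 200000 nM.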

Compound 3, half-maximal effective concentration: 69000 nM
Estimate against measurement, compound 3: 1.2-fold (0.06 log units) below; the measured number falls inside the stated range.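

Set on this aromatic carbon, ortho to a large group and meta to a carboxy group, (methoxycarbonyl)amino gives a 1.1-fold lower number from compound 1 to compound 3 (0.05 log units; within the scatter) in this assay. The earlier step exchanged the whole group on the ring nitrogen, whereas this one shows that adding 5 heavy atoms at this carbon leaves compound 3 within the scatter of compound 1. Nothing measured here speaks to why this addition makes so little difference.

Still open, as far as these compounds go, is how a plain amine or a longer chain would read at this carbon. From the compounds shown here alone, it is also open whether (methoxycarbonyl)amino would read the same on another carbon of this ring.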